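The compounds below may be only part of what the source reports. "The series", "measured", "known", "first", "only" and "open" are said of these compounds alone.

Measured so far in a physicochemical assay for lipophilicity; on this read-out higher numbers stand for higher lipophilicity and lower numbers for lower lipophilicity:
- compound 1 `Cc1cn(C2CC(N=[N+]=[N-])C(COC(=O)OCCCC(=O)OC(C)(C)C)O2)c(=O)[nH]c1=O`: 1.14
- compound 2 `Cc1cn(C2CC(N=[N+]=[N-])C(COC(=O)NCCCC(=O)O)O2)c(=O)[nH]c1=O`: -0.81

Compound 2 stands lower of the two, with a gap to compound 1 beyond the scatter. Compound 3 `Cc1cn(C2CC(N=[N+]=[N-])C(COC(=O)CCCN)O2)c(=O)[nH]c1=O` differs from compound 2 as follows: 3-aminopropyl in place of (3-carboxypropyl)amino on a carbonyl carbon. In words, 3-aminopropyl replaces (3-carboxypropyl)amino on a carbonyl carbon. Going by the values given here, no measured pair differs in one place only, so no direct precedent exists for this change. Starting from compound 2 at -0.81, a modest rise in this assay is expected. The expected change is a number 0.41 log units higher from compound 2 to compound 3 (beyond the scatter). The estimate for compound 3 is -0.4, with a range of -1.2 to 0.4.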

Compound 3, partition coefficient: -0.9
Compound 3: middle estimate off by 0.50 log units, on the high side; measured number inside the range.
By their numbers in this assay, from the lowest: compounds 3 and 2 (each within the scatter of the next); then compound 1.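

In this assay, 3-aminopropyl in place of (3-carboxypropyl)amino on a carbonyl carbon gives a number 0.09 log units lower from compound 2 to compound 3 (within the scatter). This first one-place pair shows that the read-out does not separate these two groups at this position, although the entering group has fewer heavy atoms and no double bond. No available evidence accounts for this result. Open questions are how a longer chain ending in an amine would read at this position, and whether a hydroxyl in place of the amine of 3-aminopropyl would read the same.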